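Swapping the amine substituent from chlorophenyl to cyclohexyl

The source may report more compounds than this note shows. Statements on the series, on what has been measured and on what is new or still open speak of the compounds shown alone.

Three compounds share one core and differ only in the group on a saturated chain carbon bound to an amine nitrogen in a ring. Compound 1 `COc1cc(N)c(Cl)cc1NC(=O)C1CCN(CC2CC2)CC1` carries cyclopropyl there; in a functional assay on the whole organism for antagonist activity, with Mus musculus as the target (a lower number here means that less compound is needed, a higher number that more compound is needed for the effect), compound 1 gives > 10 mg/kg, which is a limit of the assay and not a number. Compound 2 `COc1cc(N)c(Cl)cc1NC(=O)C1CCN(Cc2ccccc2Cl)CC1` carries 2-chlorophenyl; in this assay compound 2 gives > 4 mg/kg, again a limit rather than a number. Compound 3 `COc1cc(N)c(Cl)cc1NC(=O)C1CCN(Cc2ccc(O)cc2)CC1` carries 4-hydroxyphenyl; in this assay compound 3 gives > 8 mg/kg, also a limit. Because every value is a limit (the limit of > 4 mg/kg in this assay, at which 1 of the 3 values shown sits), compound 2 cannot be ranked against the other two. The measured steps are a step that the two limits leave unreadable from compound 1 to compound 2, a step that the two limits leave unreadable from compound 1 to compound 3 and a step that the two limits leave unreadable from compound 2 to compound 3, so none gives a readable size or direction.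

Compound 4 `COc1cc(N)c(Cl)cc1NC(=O)C1CCN(CC2CCCCC2)CC1` is not yet measured. It differs from compound 2 by cyclohexyl in place of 2-chlorophenyl on a saturated chain carbon bound to an amine nitrogen in a ring. Going by the values given here, no measured step bears on this change with a readable size, so the expected step from compound 2 to compound 4 in this assay is set only loosely, at a step that the limit leaves unreadable from compound 2 to compound 4, with a good chance that only another limit is reported. The estimate for compound 4 in this assay is 10 mg/kg, in a range from 3 mg/kg to 30 mg/kg.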

Compound 4, dose for half-maximal effect: 2.9 mg/kg
Compound 4: the middle estimate sits 3.4-fold (0.54 log units) above what was measured; the whole stated range lies above it.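

In this assay compound 4 is the first of these compounds to give a real number rather than a limit, so the place on a saturated chain carbon bound to an amine nitrogen in a ring now has a measured reference point. Cyclohexyl gives an at least 3.4-fold lower number from compound 1 to compound 4 (0.53 log units; beyond the scatter) and an at least 2.7-fold lower number from compound 3 to compound 4 (0.44 log units; beyond the scatter), so less compound is needed with it than with cyclopropyl or 4-hydroxyphenyl, whereas an at least 1.3-fold lower number from compound 2 to compound 4 (0.13 log units; that floor lies within the scatter) does not set it apart from 2-chlorophenyl. That last comparison yields only a small floor, not a true size, because compound 2 stands at a limit: the limit of > 4 mg/kg in this assay, at which 1 of the 4 values shown sits.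

On these data alone, the steps among compound 1, compound 2 and compound 3 still cannot be read, and the swap from 2-chlorobenzyl to cyclohexylmethyl changes both the ring and the chlorine, so the effect of each alone stays unknown. Also open, as far as these compounds go, is how an unsubstituted benzyl, a cyclopentylmethyl or a longer chain such as cyclohexylethyl would fare at this place.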